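Adding a second trifluoromethyl to a gastric-cancer cell inhibitor

A few compounds are considered here, and "the series" means these few. Any claim that something is new, unique, unknown or untested is made for them only; others in the source may bear on it.

Measured compounds:
- compound 1, `CN(C(=O)NC(=O)c1c(F)cccc1F)c1nc(C(F)(F)F)c(C(=O)N/N=C/c2cc(C(F)(F)F)cc(C(F)(F)F)c2)s1`, 5.28 ug/mL
- compound 2, `CN(C(=O)NC(=O)c1ccccc1F)c1nc(C(F)(F)F)c(C(=O)N/N=C/c2cc(C(F)(F)F)cc(C(F)(F)F)c2)s1`, 4.23 ug/mL
- compound 3, `CN(C(=O)NC(=O)c1ccc(C(F)(F)F)cc1)c1nc(C(F)(F)F)c(C(=O)N/N=C/c2cccc(C(F)(F)F)c2)s1`, 1.84 ug/mL

All three share the same core and were tested in a functional assay on BCG823 cells (Homo sapiens) for inhibition, read by MTT assay, with a stated time of 72 h; on this read-out lower numbers stand for stronger inhibition and higher numbers for weaker inhibition. Compound 3 has the lowest number of the three; compound 2 comes nearest to it, and compound 1 is furthest away, both beyond the scatter. Among the compounds with values here, the one measured step with a single change, a 1.2-fold lower number from compound 1 to compound 2 (0.10 log units; within the scatter), shows that removing a fluoro on the aromatic ring of the acyl part leaves the result within the scatter.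

Compound 4, `CN(C(=O)NC(=O)c1ccc(C(F)(F)F)cc1)c1nc(C(F)(F)F)c(C(=O)N/N=C/c2cc(C(F)(F)F)cc(C(F)(F)F)c2)s1`, differs from compound 3 in one place: trifluoromethyl in place of hydrogen on an aromatic carbon. Within the data shown here, the second trifluoromethyl makes its hydrazone aryl ring match that of compound 1 and compound 2, yet both of those compounds differ from compound 4 in the acyl part as well, so no measured step isolates this change. Compound 1 and compound 2 give higher numbers than compound 3, which hints that the doubly substituted ring may come with a somewhat weaker result, but the acyl change could account for that.

The expected step is therefore a 1.5-fold higher number from compound 3 to compound 4 (0.18 log units; within the scatter), a modest rise that may stay within the scatter. Compound 4 is estimated at 2.8 ug/mL, with a range from 1.2 ug/mL to 6.5 ug/mL.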

Compound 4, half-maximal inhibitory concentration: 1.77 ug/mL
Beside the measured number, compound 4's estimate is 1.6-fold (0.20 log units) above it, within the range that was stated.
By their numbers in this assay, from the lowest: compounds 4 and 3 (each within the scatter of the next); then compounds 2 and 1 (each within the scatter of the next).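

In this assay, the step that isolates the second trifluoromethyl gives a 1.0-fold lower number from compound 3 to compound 4 (0.02 log units; within the scatter) and so shows that this position on the aromatic ring, meta to a trifluoromethyl group, accepts the added group with no change that can be told from the scatter. With that ring now held constant, the acyl part can be read on its own, and it gives a 2.4-fold lower number from compound 2 to compound 4 (0.38 log units; beyond the scatter) for 4-(trifluoromethyl)phenyl in place of 2-fluorophenyl and a 3.0-fold lower number from compound 1 to compound 4 (0.47 log units; beyond the scatter) for the same group in place of 2,6-difluorophenyl, so among these compounds the higher numbers of compound 1 and compound 2 follow the acyl part and not the second trifluoromethyl. Nothing available here explains either the flat result on the ring or the larger steps in the acyl part.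

Trifluoromethyl is the only group shown in this position, so it remains open whether an amine, a carboxylic acid or a longer chain there would also leave the number unchanged. Within the data shown here, the acyl steps are also seen only on the ring with two trifluoromethyl groups, and whether they would hold on the ring with one remains open.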